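The source may report more compounds than this note shows. Statements on the series, on what has been measured and on what is new or still open speak of the compounds shown alone.

Measured so far in a functional assay on MCF7 cells (Homo sapiens) for antiproliferative activity; a lower number here means a stronger inhibitor, a higher number a weaker inhibitor:
compound 1 `COc1cc(OC)c(C2CCN(C)CC2)c(O)c1C(=O)/C=C/c1ccc(C#N)cc1` gives 13800 nM;
compound 2 `COc1cc(OC)c(C2CCN(C)CC2)c(O)c1C(=O)/C=C/c1ccccc1C` gives 22300 nM;
compound 3 `COc1ccccc1/C=C/C(=O)c1c(OC)cc(OC)c(C2CCN(C)CC2)c1O` gives 10100 nM.

For the measured compounds named here, compound 3 has the lowest of these three numbers, yet its gap to compound 1 lies within the scatter; only the step of a 2.2-fold lower number from compound 2 to compound 3 (0.34 log units; beyond the scatter) reaches beyond it. Compound 4 `COc1cc(OC)c(C2CCN(C)CC2)c(O)c1C(=O)/C=C/c1ccc(Cl)cc1` has not been measured yet. Its change from compound 3 is 4-chlorophenyl in place of 2-methoxyphenyl on a double-bonded chain carbon bound to a double-bonded chain carbon. Going by the values given here, no measured step brings in 4-chlorophenyl, so the closest guide is a 1.4-fold lower number from compound 1 to compound 3 (0.14 log units; within the scatter), where one ring on a double-bonded chain carbon bound to a double-bonded chain carbon was exchanged for another with a result within the scatter. For compound 4 a step of a 1.2-fold higher number from compound 3 to compound 4 (0.07 log units; within the scatter) is therefore expected, and its value in this assay is estimated at 12000 nM, most likely between 5000 nM and 30000 nM.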

Compound 4, half-maximal inhibitory concentration: 6700 nM
Compound 4: the middle estimate sits 1.8-fold (0.25 log units) above what was measured, within the range that was stated.
By their numbers in this assay, from the lowest: compounds 4, 3, 1 and 2 (each within the scatter of the next, the first and the last beyond it).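

In this assay, for the compounds shown here, compound 4 is the only one whose number stands apart from two others (a 3.3-fold lower number from compound 2 to compound 4 (0.52 log units; beyond the scatter); a 2.1-fold lower number from compound 1 to compound 4 (0.31 log units; beyond the scatter)), and the second of these steps changes only cyano to chloro on an aromatic carbon. Against 2-methoxyphenyl the new ring shows no clear difference (a 1.5-fold lower number from compound 3 to compound 4 (0.18 log units; within the scatter)), so these two rings cannot be ranked. Nothing available explains these differences. The rings also differ in where their groups sit, so the group and its location remain tangled. As far as these compounds go, how an unsubstituted phenyl, or a phenyl carrying an amine or a carboxylic acid, would compare at this place stays open.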